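Geometry change at the exocyclic double bond in the oxindole series

The source may hold more compounds than are shown below. What is called first, only, known or untested is meant among the compounds shown, and "the series" means these compounds.

Compound 3 `O=C1Nc2ccc(C(c3ccccc3)c3ccccc3)cc2/C1=C\c1cccc(OCc2cn(Cc3ccccc3)nn2)c1` stands at the assay ceiling: in a functional assay on PC-3 cells (Homo sapiens) for inhibition, read by MTT assay, with a stated time of 48 h (a higher number here means a weaker inhibitor, a lower number a stronger inhibitor), compound 3 returns only the limit > 50000 nM, not a number. Compound 1 `O=C1Nc2cc(Cl)ccc2/C1=C\c1cccc(OCc2cn(Cc3ccccc3)nn2)c1` likewise returns only the limit > 50000 nM. Compound 2 `COc1ccc(Cc2ccc3c(c2)/C(=C\c2cccc(OCc4cn(Cc5ccccc5)nn4)c2)C(=O)N3)cc1` gives a number, 32200 nM. Among the measured compounds shown here, two of the three results sit at the limit of > 50000 nM in this assay, at which 2 of the 3 values shown sit, so no measured step is available for comparison. Compound 4 `O=C1Nc2ccc(C(c3ccccc3)c3ccccc3)cc2/C1=C/c1cccc(OCc2cn(Cc3ccccc3)nn2)c1` differs from compound 3 by the two compounds have the same atoms and bonds and differ only in configuration as drawn: 1 of 1 stereo elements differ; a double bond is drawn E in compound 3 and Z in compound 4; the two compounds have the same atoms and bonds and differ only in configuration as drawn, a double bond drawn E in compound 3 and Z in compound 4. For the measured compounds named here, with no measured step covering such a change, the expected shift an at least 1.1-fold lower number from compound 3 to compound 4 (0.04 log units; that floor lies within the scatter) is small and of uncertain direction. Compound 4 is expected at 45000 nM in this assay, within 15000 nM to 100000 nM.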

Compound 4, half-maximal inhibitory concentration: 17200 nM
Compound 4: the middle estimate sits 2.6-fold (0.42 log units) above what was measured; the range from low to high includes it.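

In this assay the series now has its first measured step, an at least 2.9-fold lower number from compound 3 to compound 4 (0.46 log units; beyond the scatter). Compound 3 gives only a limit, > 50000 nM, so the true step may be larger. The double-bond configuration alone carries this change, because nothing else separates the pair: the fact that compounds 3 and 4 differ only in the configuration as drawn

On these data alone, whether the Z drawing brings a similar change to the substituted cores of compound 1 and compound 2 remains open. As far as these compounds go, how an amine or a carboxylic acid on the shared core would behave in either configuration is also open.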